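Swapping a methylphenyl amide for a trifluoromethylphenyl amide

The source may hold more compounds than are shown below. What is called first, only, known or untested is meant among the compounds shown, and "the series" means these compounds.

Measured compounds:
- compound 1, `O=C(Nc1cccc(-c2oc3cc(-c4ccc(F)cc4)ccc3c(=O)c2O)c1)c1ccc(F)cc1`, gives 9280 nM in a functional assay on HepG2 cells (Homo sapiens) for antiproliferative activity, read by CCK-8 assay, with a stated time of 72 h; on this read-out higher numbers stand for weaker inhibition and lower numbers for stronger inhibition
- compound 2, `O=C(Nc1cccc(-c2oc3cc(-c4ccc(F)cc4)ccc3c(=O)c2O)c1)c1ccc(F)cc1F`, gives 26400 nM in this assay
- compound 3, `Cc1ccccc1C(=O)Nc1cccc(-c2oc3cc(-c4ccc(F)cc4)ccc3c(=O)c2O)c1`, gives 19400 nM in this assay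

Compound 3 holds the second highest of the three numbers. Its nearest neighbour is compound 2, with a 1.4-fold lower number from compound 2 to compound 3 (0.13 log units; within the scatter), a gap that lies within the scatter; its furthest is compound 1, with a 2.1-fold higher number from compound 1 to compound 3 (0.32 log units; beyond the scatter). The third measured step is a 2.8-fold higher number from compound 1 to compound 2 (0.45 log units; beyond the scatter).

Compound 4, `O=C(Nc1cccc(-c2oc3cc(-c4ccc(F)cc4)ccc3c(=O)c2O)c1)c1ccc(C(F)(F)F)cc1`, differs from compound 3 in one place: 4-(trifluoromethyl)phenyl in place of 2-methylphenyl on a carbonyl carbon. Within the data shown here, no measured step changes the group on the carbonyl in exactly this way, so the bearing on compound 4 is indirect. Compound 1 also carries a single-substituted ring on the carbonyl, namely 4-fluorophenyl, and gives the lowest number; both steps away from compound 1 were modest. Compound 4 is therefore expected to land somewhat below compound 3 in this assay, a step of a 1.6-fold lower number from compound 3 to compound 4 (0.21 log units; within the scatter) that may not exceed the scatter. The estimate for compound 4 is 12000 nM, in the range 4000 nM to 36000 nM.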

Compound 4, half-maximal inhibitory concentration: 42700 nM
Compound 4: middle estimate off by 3.6-fold (0.55 log units), on the low side; measured number outside the range, above it.
By their numbers in this assay, from the lowest: compound 1; then compounds 3, 2 and 4 (each within the scatter of the next, the first and the last beyond it).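

At this position on the carbonyl carbon, a single substituent on the ring does not by itself keep the number low. In this assay, trifluoromethyl in place of fluoro gives a 4.6-fold higher number from compound 1 to compound 4 (0.66 log units; beyond the scatter), and 4-(trifluoromethyl)phenyl in place of 2-methylphenyl gives a 2.2-fold higher number from compound 3 to compound 4 (0.34 log units; beyond the scatter), so among the singly substituted rings here, only the 4-fluorophenyl of compound 1 has the lowest number. Against the 2,4-difluorophenyl ring, the step is a 1.6-fold higher number from compound 2 to compound 4 (0.21 log units; within the scatter), which leaves those two compounds unordered.

From the compounds shown here alone, whether an unsubstituted phenyl, or a phenyl carrying an amine or a carboxylic acid, would come closer to compound 1 stays open. Nothing available here accounts for the size of these steps.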